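Benzyl Variation and Cytotoxicity in the Series

This account rests on a few compounds, and the source may have more. Where it says the series, first, only, none or still open, it means among the compounds named here.

In an ADME assay on HEL cells (Homo sapiens) for cytotoxicity, read by microscopy, with a stated time of 3 days (a higher number here means that more compound is tolerated, a lower number that less compound is tolerated), compound 1 `CCOC(=O)C1(Cc2ccccc2)CN(c2ccccc2)Cc2nnn(Cc3ccccc3)c21` gives >= 20000 nM, which is a limit of the assay rather than a number. Compound 2 `CCOC(=O)C1(Cc2ccccc2)CN(c2ccccc2)Cc2nnn(Cc3ccc(OC)cc3)c21` gives > 100000 nM, likewise a limit. Compound 3 `CCOC(=O)C1(Cc2ccccc2)CN(c2ccccc2)Cc2nnn(Cc3cccc(Cl)c3)c21` gives > 100000 nM, again a limit. Compound 2 therefore stands at the limit of > 100000 nM in this assay, at which 2 of the 3 values shown sit, where the value of compound 3 also sits, whereas compound 1 sits at the limit of >= 20000 nM in this assay, at which 1 of the 3 values shown sits. The steps among these three are a step that the two limits leave unreadable from compound 1 to compound 2, a step that the two limits leave unreadable from compound 1 to compound 3 and a step that the two limits leave unreadable from compound 2 to compound 3: none of them can be read, since each end is a limit.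

Compound 4 `CCOC(=O)C1(Cc2ccccc2)CN(c2ccccc2)Cc2nnn(Cc3c(F)cccc3Cl)c21` has not yet been measured. It differs from compound 2 by 2-chloro-6-fluorophenyl in place of 4-methoxyphenyl on a saturated chain carbon bound to an aromatic nitrogen. The step from compound 2 to compound 3 is the nearest comparison, since it also changes the group on the same saturated chain carbon, and it too is unreadable. No readable step bears on this change, so in this assay no step beyond the scatter is expected in either direction. The expected step from compound 2 to compound 4 is a number no higher from compound 2 to compound 4 (the limit leaves the size open). Compound 4 is expected to give 100000 nM, within 30000 nM to 100000 nM, and most likely to be reported once more only as a limit.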

Compound 4, minimum cytotoxic concentration: > 100000 nM
Compound 4 gave a limit, no number (the forecaster's own chance of this, stated with the estimate: 80%); the middle value sits exactly at the limit.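

In this assay compound 4 gives > 100000 nM, which is a limit and not a number. Its steps to compound 1, compound 2 and compound 3 cannot be read. The compounds shown leave open whether varying the benzyl group on the shared core moves the minimum cytotoxic concentration at all, and in which direction.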